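This account rests on a few compounds, and the source may have more. Where it says the series, first, only, none or still open, it means among the compounds named here.

In an in vitro ADME assay on microsomes from liver (Homo sapiens) for metabolic stability (on this read-out lower numbers stand for slow clearance and higher numbers for fast clearance), compound 1 `CC(C)NC(=O)[C@H]1CC[C@@H](n2/c(=N/C(=O)c3ccc(C#N)c(F)c3)[nH]c3ccc(CN4CCC(C(C)(C)O)CC4)cc32)CC1` gives 132 mL.min-1.g-1 as its number, within the usual scatter of compound 2 `COC(=O)[C@H]1CC[C@@H](n2/c(=N/C(=O)c3ccccc3)[nH]c3ccc(CN4CCCCC4)cc32)CC1` at 85 mL.min-1.g-1 on the same scale. Compound 3 `CC(C)NC(=O)[C@H]1CC[C@@H](n2/c(=N/C(=O)c3ccc(F)cc3)[nH]c3ccc(CN4CCCCC4)cc32)CC1` reads 302 mL.min-1.g-1 and so stands clearly higher than compound 1, beyond that scatter. The unmeasured compound 4 `CC(C)NC(=O)[C@H]1CC[C@@H](n2/c(=N/C(=O)c3cccc(C#N)c3)[nH]c3ccc(CN4CCC(C(C)(C)O)CC4)cc32)CC1` keeps the rest of compound 1 and changes one group, with 3-cyanophenyl in place of 4-cyano-3-fluorophenyl on a carbonyl carbon. The counted difference 3-cyanophenyl in place of 4-cyano-3-fluorophenyl on a carbonyl carbon is the whole of the change. Within the data shown here, no two measured compounds differ in one place only, so the data offer no direct guide to this swap. The expectation therefore starts from compound 1 at 132 mL.min-1.g-1 as the closest relative, and in this assay no shift beyond the scatter is expected. The estimated step is a 1.1-fold lower number from compound 1 to compound 4 (0.04 log units; within the scatter) and stays inside that scatter. Compound 4 is estimated at 120 mL.min-1.g-1 with 60 mL.min-1.g-1 to 240 mL.min-1.g-1 as the expected range.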

Compound 4, intrinsic clearance in microsomes: 72 mL.min-1.g-1
Estimate against measurement, compound 4: 1.7-fold (0.22 log units) above; measured number inside the range.
By their numbers in this assay, from the lowest: compounds 4, 2 and 1 (each within the scatter of the next); then compound 3.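

In this assay, 3-cyanophenyl in place of 4-cyano-3-fluorophenyl on a carbonyl carbon gives a 1.8-fold lower number from compound 1 to compound 4 (0.26 log units; within the scatter), the only comparison shown in which just one place differs. Compound 1 and compound 4 therefore cannot be told apart on this read-out, so at this place, this change, which takes out one fluorine and leaves a differently substituted cyanophenyl, makes no difference larger than repeat measurements would. Nothing at hand bears on why the two compounds read alike.

The fluorine and the nitrile changed together here, so the part each plays cannot be separated. As far as these compounds go, it also remains open how a different ring on the carbonyl carbon, such as pyridyl or thienyl, would read in this assay.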